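The compounds below may be only part of what the source reports. "The series", "measured", "known", "first", "only" and "open" are said of these compounds alone.

Measured so far:
compound 1, `CCOC(=O)c1c(C)nc(-c2cccc(C#N)c2)n1O`: 17600 nM
compound 2, `C=CCOn1c(-c2cccc(C#N)c2)nc(C)c1C(=O)OCC`: 5860 nM

Both numbers come from a functional assay on a cell-free system (plasma, Oryctolagus cuniculus) for inhibition, with stated times of 5 min, 1 min and 6 min; on this read-out higher numbers stand for weaker inhibition and lower numbers for stronger inhibition. Among the measured compounds shown here, compound 2 holds the lower of the two numbers; its only neighbour is compound 1, a step of a 3.0-fold lower number from compound 1 to compound 2 (0.48 log units; beyond the scatter) away. That step put allyl in place of hydrogen on an oxygen on an aromatic ring and gave a stronger inhibitor.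

Compound 3, `CCOC(=O)c1c(C)nc(-c2cccc(C#N)c2)n1OCc1ccncc1`, keeps the substituted oxygen but changes the far end of the chain on it: pyridin-4-yl in place of vinyl on a saturated chain carbon bound to an oxygen on an aromatic ring. For the measured compounds named here, only the step from compound 1 to compound 2 bears on this, because a 3.0-fold lower number from compound 1 to compound 2 (0.48 log units; beyond the scatter) is the sole measured change at that oxygen; it was modest and beyond the scatter, and showed that adding allyl there lowered the number. Whether a larger, ring-bearing group continues that direction is shown by no measured pair, so the expectation is weak. A modest further drop in this assay is expected, a 2.0-fold lower number from compound 2 to compound 3 (0.29 log units; within the scatter), with a wide range that allows for no change at all. Compound 3 is therefore estimated at 3000 nM, between 800 nM and 12000 nM.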

Compound 3, half-maximal inhibitory concentration: 6200 nM
Estimate against measurement, compound 3: 2.1-fold (0.32 log units) below, within the range that was stated.
By their numbers in this assay, from the lowest: compounds 2 and 3 (each within the scatter of the next); then compound 1.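

In this assay, pyridin-4-yl at the end of the chain in place of vinyl gives a 1.1-fold higher number from compound 2 to compound 3 (0.02 log units; within the scatter), so this read-out does not separate the allyl group from the (pyridin-4-yl)methyl group, even though only the second carries an aromatic ring. Against the parent with hydrogen on the oxygen, the (pyridin-4-yl)methyl group gives a 2.8-fold lower number from compound 1 to compound 3 (0.45 log units; beyond the scatter), a modest step beyond the scatter, so a second and quite different group at this oxygen also goes with stronger inhibition than hydrogen does. Across these three compounds, the measurable difference therefore lies between hydrogen and either substituent, and not between the two substituents themselves.

The data shown include no measurement that accounts for this result. From the compounds shown here alone, it remains open whether a small methyl group, a longer saturated chain, a benzyl group with no ring nitrogen, or a chain ending in an amine on the same oxygen would land near compound 2 and compound 3, or whether one of them would move the number clearly away from both.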